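Longer Amide Chains and Cytotoxicity in SW1573 Cells

The source may report more compounds than this note shows. Statements on the series, on what has been measured and on what is new or still open speak of the compounds shown alone.

Among the compounds with values here, in a functional assay on SW1573 cells (Homo sapiens) for cytotoxicity, read by sulforhodamine B assay, with a stated time of 72 h (on this read-out higher numbers stand for weaker inhibition and lower numbers for stronger inhibition), compound 1 `CC(=O)Nc1ccn([C@@H]2CO[C@H](CO)O2)c(=O)n1` gives 10700 nM and compound 2 `CCCC(=O)Nc1ccn([C@@H]2CO[C@H](CO)O2)c(=O)n1` gives 8070 nM at the high end of the numbers so far, level within the scatter. Compound 3 `CCCCCCC(=O)Nc1ccn([C@@H]2CO[C@H](CO)O2)c(=O)n1` gives 2400 nM as a clearly lower value. Compound 4 `CCCCCCCCC(=O)Nc1ccn([C@@H]2CO[C@H](CO)O2)c(=O)n1` differs from compound 1 by heptyl in place of hydrogen on a saturated chain carbon bound to a carbonyl carbon with heptyl in place of hydrogen on a saturated chain carbon bound to a carbonyl carbon. Within the data shown here, three measured steps bear on this change. Ethyl in that place gives a 1.3-fold lower number from compound 1 to compound 2 (0.12 log units; within the scatter) and so no real change, which goes against any simple rule that each lengthening lowers the number. Pentyl gives a 4.5-fold lower number from compound 1 to compound 3 (0.65 log units; beyond the scatter) and the comparison of the two longer chains gives a 3.4-fold lower number from compound 2 to compound 3 (0.53 log units; beyond the scatter) as well. Heptyl is longer still, so a further modest drop is expected, though three compounds are thin support. The expected size is a 9.7-fold lower number from compound 1 to compound 4 (0.99 log units; beyond the scatter) in this assay on this estimate. Compound 4 is estimated at 1100 nM with 400 nM to 3000 nM as the likely range.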

Compound 4, half-maximal inhibitory concentration: 276 nM
Compound 4: the middle estimate sits 4.0-fold (0.60 log units) above what was measured, outside the stated range (below it).
By their numbers in this assay, from the lowest: compound 4; then compound 3; then compounds 2 and 1 (each within the scatter of the next).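

Going from hydrogen to heptyl gives a 39-fold lower number from compound 1 to compound 4 (1.59 log units; beyond the scatter) in this assay, so this position accepts a much longer chain than the earlier compounds reached, and the numbers are still falling at compound 4. The drop also grows along the series, with the last lengthening alone giving an 8.7-fold lower number from compound 3 to compound 4 (0.94 log units; beyond the scatter), while the same ethyl change on the shortest chain gives no real change: the same change on two cores in this assay, a 1.3-fold lower number (0.12 log units; within the scatter) from compound 1 to compound 2 and an 8.7-fold lower number (0.94 log units; beyond the scatter) from compound 3 to compound 4, 6.6-fold (0.82 log units) apart, beyond the scatter of two such steps Pentyl shows the same pattern, with a 29-fold lower number from compound 2 to compound 4 (1.47 log units; beyond the scatter) standing well apart from the same change made on a shorter chain: the same change on two cores in this assay, a 4.5-fold lower number (0.65 log units; beyond the scatter) from compound 1 to compound 3 and a 29-fold lower number (1.47 log units; beyond the scatter) from compound 2 to compound 4, 6.6-fold (0.82 log units) apart, beyond the scatter of two such steps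

From the compounds shown here alone, whether a chain longer than heptyl lowers the number further or the fall levels off remains open. So does whether a chain ending in an amine or a carboxylic acid would keep this gain.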